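Chloro in place of fluoro: clearance notes on compound 4

A few compounds are considered here, and "the series" means these few. Any claim that something is new, unique, unknown or untested is made for them only; others in the source may bear on it.

Two cores are in hand. Compound 1 `O=C(COCc1ccccc1)N1CCN(c2ccc(Cl)cc2Cl)CC1` and compound 2 `O=C(COCc1ccccc1)N1CCN(c2ccc(F)cc2Cl)CC1` share one core, while compound 3 `O=C(COCc1ccncc1)N1CCC(c2ccc(F)cc2Cl)CC1` and the unmeasured compound 4 `O=C(COCc1ccncc1)N1CCC(c2ccc(Cl)cc2Cl)CC1` share another. The difference between the two cores is not broken down here; the structures stand beside the compounds.

In an in vitro ADME assay on microsomes from liver (Homo sapiens) for metabolic stability (on this read-out higher numbers stand for fast clearance and lower numbers for slow clearance), compound 1 gives 450 mL.min-1.g-1. In this assay compound 2 gives 530 mL.min-1.g-1. Compound 3 gives 56 mL.min-1.g-1 in this assay, the lowest of the three numbers, and its gaps to compound 1 and to compound 2 both lie beyond the scatter of repeated measurements.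

Within the first core the one change on record is chloro in place of fluoro on an aromatic carbon. This change made a 1.2-fold lower number from compound 2 to compound 1 (0.07 log units; within the scatter), so the two values show no real movement.

The change from compound 3 to compound 4 is chloro in place of fluoro on an aromatic carbon. Among the compounds with values here, its place line is the same word for word as the one from compound 2 to compound 1, so it is the same change, carried onto the second core. For compound 4 the step is therefore expected to stay small, a 1.1-fold lower number from compound 3 to compound 4 (0.05 log units; within the scatter), because the same change gave a 1.2-fold lower number from compound 2 to compound 1 (0.07 log units; within the scatter) in this assay. Compound 4 is estimated at 50 mL.min-1.g-1 in this assay, with the number expected to fall between 25 mL.min-1.g-1 and 100 mL.min-1.g-1.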

Compound 4, intrinsic clearance in microsomes: 96 mL.min-1.g-1
For compound 4 the middle estimate is 1.9-fold (0.28 log units) below the measured one; the measured number falls inside the stated range.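

Working notes on the second core: in this assay, chloro in place of fluoro on an aromatic carbon gives a 1.7-fold higher number from compound 3 to compound 4 (0.23 log units; within the scatter), so the 2-chloro-4-fluorophenyl to 2,4-dichlorophenyl change leaves the clearance read-out within what repeated measurements would scatter over. Set against the first core, the change carries across the two cores without a detectable difference in size: the same change on two cores in this assay, a 1.2-fold lower number (0.07 log units; within the scatter) from compound 2 to compound 1 and a 1.7-fold higher number (0.23 log units; within the scatter) from compound 3 to compound 4, 2.0-fold (0.31 log units) apart, within the scatter of two such steps

This shows only that, on these two pairs, the change stays inside the scatter on both cores; the opposite directions of the two steps carry no weight, and two pairs do not establish that the change would stay as quiet on any further core, nor do they say why it does so here.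

The compounds shown cover only fluoro and chloro on this aromatic carbon, so whether a nitrile, a methoxy group or a trifluoromethyl group in the same place would also leave the read-out within the scatter stays open. Within the data shown here, also open is how much of the gap between the two cores belongs to each part of the structure in which they differ, since no pair here separates those parts.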